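Cytotoxicity notes: aryl variation on the shared core

The source may hold more compounds than are shown below. What is called first, only, known or untested is meant among the compounds shown, and "the series" means these compounds.

compound 1 `CCc1c(Cc2ccccc2Br)nc(SCc2ccc([N+](=O)[O-])cc2)[nH]c1=O`: > 272000 nM
compound 2 `CCc1c(Cc2cc(C)cc(C)c2)nc(SCc2ccc([N+](=O)[O-])cc2)[nH]c1=O`: > 305000 nM

Compound 1 carries a 2-bromophenyl on a saturated chain carbon bound to an aromatic carbon; compound 2 carries a 3,5-dimethylphenyl at that place. In an ADME assay on MT4 cells (Homo sapiens) for cytotoxicity, read by MTT assay (on this read-out higher numbers stand for lower toxicity in this test and lower numbers for higher toxicity in this test), compound 1 gives > 272000 nM, which is a limit of the assay and not a number. In this assay compound 2 gives > 305000 nM, likewise a limit. The step that the two limits leave unreadable from compound 1 to compound 2 is of unreadable size, the two values sitting at the limit of > 272000 nM in this assay, at which 1 of the 2 values shown sits, and (the limit of > 305000 nM in this assay, at which 1 of the 2 values shown sits). For the measured compounds named here, compound 2 thus stands at a limit, and the one further value shown is a limit too; no order between the two compounds can be read.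

Compound 3 `CCc1c(Cc2c(Cl)cccc2Cl)nc(SCc2ccc([N+](=O)[O-])cc2)[nH]c1=O` differs from compound 2 by 2,6-dichlorophenyl in place of 3,5-dimethylphenyl on a saturated chain carbon bound to an aromatic carbon. Going by the values given here, the only measured step, from compound 1 to compound 2, also exchanges the aryl on that saturated chain carbon, and its size is not readable, so no step of known size bears on the present change. Compound 3 is expected to sit at a limit in this assay as well. The step of an at least 1.0-fold lower number from compound 2 to compound 3 (0.00 log units; that floor lies within the scatter) is expected to be none beyond the scatter. Compound 3 is accordingly estimated at 300000 nM, with a range from 100000 nM to 600000 nM.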

Compound 3, half-maximal cytotoxic concentration: > 278000 nM
Compound 3: only a limit was reported; the forecaster's own chance of this, stated with the estimate: 80%; the middle value is on the limit's open side.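

In this assay compound 3 gives > 278000 nM and this is a limit, not a number. For the compounds shown here, with compound 1, compound 2 and compound 3 all at limits, no step among them can be read. The compounds shown leave open whether exchanging the aryl on the saturated chain carbon changes this read-out at all.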